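The source may hold more compounds than are shown below. What is called first, only, known or untested is meant among the compounds shown, and "the series" means these compounds.

Compound 1 `C[C@H](Nc1ncnc2[nH]cnc12)c1cc2ccccn2c(=O)c1-c1ccccc1` is the starting point of this short comparison. In an assay on 786-0 cells for inhibition of phosphatidylinositol 4,5-bisphosphate 3-kinase catalytic subunit beta isoform (Homo sapiens), with a stated time of 1 h (on this read-out higher numbers stand for weaker inhibition and lower numbers for stronger inhibition), measured after the stated hour of exposure on the kidney-cancer cell line, compound 1 has as its recorded result "not determined" (no result reported), so no single number describes where it stands. A related compound, compound 2 `Cc1cccc2cc([C@H](C)Nc3ncnc4[nH]cnc34)c(-c3ccccc3)c(=O)n12`, carries a methyl group on the shared core and was measured; in this assay compound 2 gives 515 nM. Among the measured compounds shown here, no step between compound 1 and compound 2 is given, so nothing can be said about how the two compare beyond what the one measured value shows.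

The new compound, compound 3 `C[C@H](Nc1ncnc2[nH]cnc12)c1cc2ccc(F)cn2c(=O)c1-c1ccccc1`, differs from compound 1 in a single place: fluoro in place of hydrogen on an aromatic carbon. Fluoro takes the place of hydrogen on an aromatic carbon of the six-membered aromatic ring with one nitrogen, two atoms from the ring nitrogen. A change this small, one heavy atom and no new donor or acceptor, is expected to shift the half-maximal inhibitory concentration in this assay by no more than the usual scatter, and in no particular direction. Taking compound 2 at 515 nM as the only anchor, compound 3 is expected to give roughly 450 nM, within a range from 120 nM to 1700 nM.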

Compound 3, half-maximal inhibitory concentration: 191 nM
For compound 3 the middle estimate is 2.4-fold (0.37 log units) above the measured one; low and high end bracket the measured number.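

In this assay, among the compounds shown here, compound 1 has the result "not determined" (no result reported) and no step from it to compound 3 can be read. The compounds shown leave open whether fluoro in place of hydrogen on this aromatic carbon changes inhibition at all. Nothing available bears on the value found for compound 3.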